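The compounds below may be only part of what the source reports. "The series", "measured", "known", "first", "only" and "open" are said of these compounds alone.

Measured so far in a functional assay on Maver1 cells (Homo sapiens) for inhibition, read by luminescence and CellTiter-Glo, with a stated time of 72 h; a higher number here means a weaker inhibitor, a lower number a stronger inhibitor:

compound 1, `O=C(CCl)Nc1cccc(Cn2nc(-c3ccc(Oc4ccccc4)cc3)cc2CO)c1`: 400 nM
compound 2, `CCOC(=O)c1cc(-c2ccc(Oc3ccccc3)cc2)nn1Cc1cccc(NC(=O)CCl)c1`: 500 nM
compound 3, `C/C=C/C(=O)N1CCCC(n2nc(-c3ccc(Oc4ccccc4)cc3)cc2C(=O)O)C1`: recorded only as a limit of this assay, > 60000 nM

Compound 2 holds the highest of the two numbers in this assay; its nearest neighbour is compound 1, and the step of a 1.3-fold higher number from compound 1 to compound 2 (0.10 log units; within the scatter) lies within the scatter. Among the compounds with values here, compound 3 sits at the limit of > 60000 nM in this assay, at which 1 of the 3 values shown sits, and, with several changes against compound 2, yields no step.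

Compound 4, `C/C=C/C(=O)Nc1cccc(Cn2nc(-c3ccc(Oc4ccccc4)cc3)cc2C(=O)OCC)c1`, is not yet measured. Against compound 2 the change is prop-1-en-1-yl in place of chloromethyl on a carbonyl carbon. Within the data shown here, no measured step concerns this position: the one step on record, a 1.3-fold higher number from compound 1 to compound 2 (0.10 log units; within the scatter), touches ethoxycarbonyl in place of hydroxymethyl on an aromatic carbon and not the carbonyl carbon altered here. Compound 3 carries a (prop-1-en-1-yl)carbonyl but differs from compound 2 in more than one place, so its limit cannot be converted into a step. Among the measured compounds shown here, the expectation for compound 4 therefore rests on no measured step; a move to a higher number is expected, a 6.0-fold higher number from compound 2 to compound 4 (0.78 log units; beyond the scatter), with wide uncertainty. Compound 4 is estimated at 3000 nM, within 600 nM to 30000 nM.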

Compound 4, half-maximal inhibitory concentration: 14200 nM
Beside the measured number, compound 4's estimate is 4.7-fold (0.68 log units) below it; the range from low to high includes it.
By their numbers in this assay, from the lowest: compounds 1 and 2 (each within the scatter of the next); then compound 4. At a limit, above all of these: compound 3.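

Notes on the series: in this assay, prop-1-en-1-yl in place of chloromethyl on a carbonyl carbon gives a 28-fold higher number from compound 2 to compound 4 (1.45 log units; beyond the scatter) as the first measured step at this position. Within the data shown here, the only earlier step, a 1.3-fold higher number from compound 1 to compound 2 (0.10 log units; within the scatter) for ethoxycarbonyl in place of hydroxymethyl on an aromatic carbon, lies within the scatter, so this carbonyl carbon is the first position to show a large response. Chloromethyl and prop-1-en-1-yl are not interchangeable here in this pair, and nothing measured so far gives a cause for the step.

The compounds shown leave open how a methyl, an ethenyl or a longer chain on this carbonyl carbon would read, and so whether the step follows the chlorine or the carbon chain. From the compounds shown here alone, it also remains open whether hydroxymethyl in place of ethoxycarbonyl would stay within the scatter with prop-1-en-1-yl present.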